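Swapping the basic amine on the urea series

The source may hold more compounds than are shown below. What is called first, only, known or untested is meant among the compounds shown, and "the series" means these compounds.

Compound 2, `COc1cc2c(Oc3c(F)cc(NC(=O)NN4C(=O)CSC4c4c(F)cccc4F)cc3F)ccnc2cc1OCCCN1CCc2sccc2C1`, sits at the edge of what the test can report: in a functional assay on A549 cells (Homo sapiens) for antiproliferative activity, read by MTT assay, with a stated time of 72 h (on this read-out higher numbers stand for weaker inhibition and lower numbers for stronger inhibition), compound 2 gives > 20000 nM, which is a limit rather than a number, as noted in the limit of > 20000 nM in this assay, at which 1 of the 2 values shown sits. Compound 1, `COc1cc2c(Oc3c(F)cc(NC(=S)NN4C(=O)CSC4c4c(F)cccc4F)cc3F)ccnc2cc1OCCCN1CCCC1`, carries a thiourea and a pyrrolidine in place of the urea and the fused amine of compound 2, and in this assay compound 1 gives 690 nM; the two differ in more than one place, so their values are simply set side by side. Compound 3, `COc1cc2c(Oc3c(F)cc(NC(=O)NN4C(=O)CSC4c4c(F)cccc4F)cc3F)ccnc2cc1OCCCN1CCC(N2CCCCC2)CC1`, keeps the urea of compound 2 and changes only the amine end of the chain: a group of 12 heavy atoms (10 carbon, 2 nitrogen; 2 six-membered non-aromatic rings with 1 hetero atom each) in place of a group of 9 heavy atoms (7 carbon, 1 nitrogen, 1 sulfur; one five-membered aromatic ring with 1 hetero atom, one six-membered non-aromatic ring with 1 hetero atom), on a saturated chain carbon, three bonds along the chain from an oxygen on an aromatic ring. Compound 3 is expected to remain weak, with an at least 2.5-fold lower number from compound 2 to compound 3 (0.39 log units; beyond the scatter) taken as a modest gain at best because compound 2 gives > 20000 nM. Compound 3 is estimated at 8000 nM in this assay, with a range from 1500 nM to 30000 nM.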

Compound 3, half-maximal inhibitory concentration: 380 nM
For compound 3 the middle estimate is 21-fold (1.32 log units) above the measured one; the whole stated range lies above it.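

At the amine end of the chain, on a saturated chain carbon, three bonds along the chain from an oxygen on an aromatic ring, the urea series proves highly sensitive to the group attached: in this assay, 4-(piperidin-1-yl)piperidin-1-yl in place of the group with the five-membered aromatic ring gives an at least 52-fold lower number from compound 2 to compound 3 (1.72 log units; beyond the scatter). The urea therefore does not rule out antiproliferative activity, since compound 3 keeps it and gives 380 nM. The step is only a lower bound on the change because compound 2 stands at a limit and not at a number: the limit of > 20000 nM in this assay, at which 1 of the 3 values shown sits.

On these data alone, it remains open whether the second piperidine ring is needed, or whether a single morpholine or a dimethylamino group at the same place would serve as well. As far as these compounds go, the effect of a longer chain carrying the 4-(piperidin-1-yl)piperidin-1-yl group also remains open.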